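A few compounds are considered here, and "the series" means these few. Any claim that something is new, unique, unknown or untested is made for them only; others in the source may bear on it.

Working notes. Compound 1 `CN(C)c1ccc(C(=O)N[C@@H](CCCCCC(=O)NO)C(=O)NCc2ccccc2)cc1`, compound 2 `O=C(CCCCC[C@H](NC(=O)OCc1ccccc1)C(=O)NCc1ccccc1)NO` and compound 3 `O=C(CCCCC[C@H](NC(=O)c1ccc(C(F)(F)F)cc1)C(=O)NCc1ccccc1)NO` share one core and differ only in the group on a carbonyl carbon. In a functional assay on NFF cells (Homo sapiens) for antiproliferative activity (a higher number here means a weaker inhibitor, a lower number a stronger inhibitor), compound 1 gives 12000 nM, compound 2 gives 1520 nM and compound 3 gives 1610 nM. Compound 2 thus holds the lowest number of the three, with compound 3 within the scatter (a 1.1-fold higher number from compound 2 to compound 3 (0.02 log units; within the scatter)) and compound 1 clearly apart (a 7.9-fold lower number from compound 1 to compound 2 (0.90 log units; beyond the scatter); likewise a 7.5-fold lower number from compound 1 to compound 3 (0.87 log units; beyond the scatter)). Compound 4 `O=C(CCCCC[C@H](NC(=O)OCc1ccccc1)C(=O)NCc1ccncc1)NO` alters another part of compound 2: pyridin-4-yl in place of phenyl on a saturated chain carbon bound to an amide-type nitrogen. Going by the values given here, none of the three measured steps touches this position, so no measured step bears on the change and nothing argues for a move beyond the scatter. The expected step is a 1.2-fold higher number from compound 2 to compound 4 (0.07 log units; within the scatter) in this assay. Compound 4 is estimated at 1800 nM, with a range of 700 nM to 4500 nM.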

Compound 4, half-maximal inhibitory concentration: 23300 nM
Beside the measured number, compound 4's estimate is 13-fold (1.11 log units) below it; measured number above the stated range.
By their numbers in this assay, from the lowest: compounds 2 and 3 (each within the scatter of the next); then compounds 1 and 4 (each within the scatter of the next).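

Going by these compounds alone, the benzyl end of the amide proved sensitive in a way the earlier compounds, which varied only the group on the carbonyl carbon, could not show. In this assay, within the data shown here, pyridin-4-yl in place of phenyl on a saturated chain carbon bound to an amide-type nitrogen gives a 15-fold higher number from compound 2 to compound 4 (1.19 log units; beyond the scatter), with one ring carbon exchanged for nitrogen as the only change. No available data bear on the cause of this rise.

Open, from the compounds shown here alone, is whether pyridin-3-yl or a cyclohexyl ring would behave alike at this position. Also open, going by these compounds, is whether the same exchange holds with 4-(trifluoromethyl)phenyl on the carbonyl carbon.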